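Acylurea thiazole hydrazones: acyl aryl swap on compound 1

The compounds below may be only part of what the source reports. "The series", "measured", "known", "first", "only" and "open" are said of these compounds alone.

Measured compounds:
compound 1 `CN(C(=O)NC(=O)c1ccc(F)c(F)c1)c1nc(C(F)(F)F)c(C(=O)N/N=C/c2ccc(C(F)(F)F)cc2)s1` — 6.07 ug/mL
compound 2 `CN(C(=O)NC(=O)c1ccc([N+](=O)[O-])cc1)c1nc(C(F)(F)F)c(C(=O)N/N=C/c2ccc([N+](=O)[O-])cc2)s1` — 8.98 ug/mL
compound 3 `CN(C(=O)NC(=O)c1ccc(F)c(F)c1)c1nc(C(F)(F)F)c(C(=O)N/N=C/c2ccccc2C(F)(F)F)s1` — 6.96 ug/mL

In a functional assay on A549 cells (Homo sapiens) for inhibition, read by MTT assay, with a stated time of 72 h (on this read-out higher numbers stand for weaker inhibition and lower numbers for stronger inhibition), compound 1 gives the lowest of the three numbers, but its gap to compound 3 (a 1.1-fold higher number from compound 1 to compound 3 (0.06 log units; within the scatter)) and its gap to compound 2 both sit within the scatter, so no order among the three can be claimed. Compound 4 `CN(C(=O)NC(=O)c1ccc(C(F)(F)F)cc1)c1nc(C(F)(F)F)c(C(=O)N/N=C/c2ccc(C(F)(F)F)cc2)s1` is not yet measured. It differs from compound 1 by 4-(trifluoromethyl)phenyl in place of 3,4-difluorophenyl on a carbonyl carbon. Among the compounds with values here, no measured step touches the acyl aryl group; the only step known, from compound 1 to compound 3, moves the trifluoromethyl on the other aryl and leaves the number essentially unchanged. All three measured values lie close together whatever the aryl substitution, so the expected step of a 1.1-fold higher number from compound 1 to compound 4 (0.03 log units; within the scatter) is none beyond the scatter. Compound 4 is estimated at 6.5 ug/mL, within 3.5 ug/mL to 12 ug/mL.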

Compound 4, half-maximal inhibitory concentration: > 100 ug/mL
Compound 4 ended at the assay's limit (the forecaster's own chance of this, stated with the estimate: 3%); at least 15-fold (1.18 log units) between middle value and limit.
By their numbers in this assay, from the lowest: compounds 1, 3 and 2 (each within the scatter of the next). At a limit, above all of these: compound 4.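

In this assay, within the data shown here, the change of 3,4-difluorophenyl to 4-(trifluoromethyl)phenyl on a carbonyl carbon is the first single change to move the read-out beyond the scatter: an at least 16-fold higher number from compound 1 to compound 4 (1.21 log units; beyond the scatter). Among these compounds, the only earlier single change, on the other aryl group, stayed within the scatter: a 1.1-fold higher number from compound 1 to compound 3 (0.06 log units; within the scatter). The result for compound 4 is a limit of the assay and not a number: the limit of > 100 ug/mL in this assay, at which 1 of the 4 values shown sits.

Going by these compounds, the true size of this step therefore remains open. On these data alone, it is also open whether a methyl, a methoxy or an amine on this phenyl ring would retain the number of compound 1.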